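Swapping the Tetrazole Arm for a New Five-Membered Ring

This account rests on a few compounds, and the source may have more. Where it says the series, first, only, none or still open, it means among the compounds named here.

Of the compounds shown here, two have been measured so far. Compound 1 `CC(C)C(Cc1ncc[nH]1)c1ccc(-c2ccc3cccc(F)c3c2)[nH]c1=O` gives 11 nM in an assay on CHO cells for displacement of a labelled ligand from prostaglandin E2 receptor EP3 subtype (Homo sapiens), read by radioligand binding (a lower number here means a stronger inhibitor, a higher number a weaker inhibitor), and compound 2 `CC(C)C(Cc1nnn[nH]1)c1ccc(-c2ccc3cccc(F)c3c2)[nH]c1=O` gives 34 nM in the same assay. Compound 2 therefore carries the highest of the two numbers, its nearest neighbour being compound 1, and the step of a 3.1-fold higher number from compound 1 to compound 2 (0.49 log units; beyond the scatter) shows that replacing 1H-imidazol-2-yl by 1H-tetrazol-5-yl on the saturated chain carbon, two bonds along the chain from an aromatic carbon, weakened binding modestly.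

Compound 3 `CC(C)C(c1noc(=O)[nH]1)c1ccc(-c2ccc3cccc(F)c3c2)[nH]c1=O` has not yet been measured. It differs from compound 2 by a group of 6 heavy atoms (2 carbon, 2 nitrogen, 2 oxygen; one five-membered aromatic ring with 3 hetero atoms) in place of a group of 6 heavy atoms (2 carbon, 4 nitrogen; one five-membered aromatic ring with 4 hetero atoms), on a saturated chain carbon bound to an aromatic carbon and a saturated chain carbon. For the measured compounds named here, only the step from compound 1 to compound 2 bears on this change, and it concerns the same position: it showed that exchanging the small five-membered heterocycle there moves the number by a modest amount, with no clear direction for a new ring. A change of similar size in either direction is therefore expected, centred near the present value. Compound 3 is estimated at 40 nM in this assay, within 10 nM to 160 nM, meaning an expected step of a 1.2-fold higher number from compound 2 to compound 3 (0.07 log units; within the scatter).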

Compound 3, inhibition constant in the prostaglandin E2 receptor EP3 subtype assay: 15 nM
The estimate for compound 3 lay 2.7-fold (0.43 log units) above the measured number; measured number inside the range.
By their numbers in the prostaglandin E2 receptor EP3 subtype assay, from the lowest: compounds 1 and 3 (each within the scatter of the next); then compound 2.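

In the prostaglandin E2 receptor EP3 subtype assay compound 2 gives 34 nM and compound 3 gives 15 nM. In the prostaglandin E2 receptor EP3 subtype assay the step of a 2.3-fold lower number from compound 2 to compound 3 (0.36 log units; beyond the scatter) shows that binding at this position does not depend on keeping the (1H-tetrazol-5-yl)methyl group, since the new five-membered ring with 3 hetero atoms gives a measurable gain over it. The step of a 1.4-fold higher number from compound 1 to compound 3 (0.13 log units; within the scatter) places the new group level with the imidazole arm of compound 1, so two quite different rings now give matching binding on this saturated chain carbon, while the tetrazole arm stands apart from both. In a physicochemical assay for solubility, measured as kinetic solubility, at pH 2 (a higher number here means a more soluble compound, a lower number a less soluble compound), compound 2 gives 28000 nM and compound 3 gives 23200 nM. In the physicochemical assay the step of a 1.2-fold lower number from compound 2 to compound 3 (0.08 log units; within the scatter) shows that this gain in binding came with no real shift in the solubility read-out.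

The (1H-tetrazol-5-yl)methyl group leaves as a whole, so the ring and its methyl link change together in this step, the two effects cannot be separated, and nothing at hand accounts for the shift. Also open, from the compounds shown here alone, is whether a carboxylic acid or a longer chain carrying the same new ring on this carbon would hold binding at this level.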